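Swapping the amine side chain on a sulfamate inhibitor

The compounds below may be only part of what the source reports. "The series", "measured", "known", "first", "only" and "open" are said of these compounds alone.

Of the compounds shown here, three sharing one core have been tested in an assay on HEK293 cells for inhibition of Steryl-sulfatase (Homo sapiens), tested at 1 uM; on this read-out lower numbers stand for a weaker effect and higher numbers for a stronger effect at the one concentration tested. Compound 1 `CCN(Cc1ccccn1)c1ccc(C(=O)N2CCc3ccc(OS(N)(=O)=O)cc3C2)cc1` gives 87.7%. Compound 2 `CC(C)CCN(CCC(C)C)c1cccc(C(=O)N2CCc3ccc(OS(N)(=O)=O)cc3C2)c1` gives 75.9%, and compound 3 `CCN(Cc1ccc(F)cc1)c1cccc(C(=O)N2CCc3ccc(OS(N)(=O)=O)cc3C2)c1` gives 66.5%. Compound 3 therefore stands lowest of the three, though its gap to compound 2 lies within the scatter; only compound 1 sits beyond the scatter above it. Going by the values given here, the one measured single change, a number 9.4 percentage points lower from compound 2 to compound 3 (within the scatter), swapped one amine substituent for another on the same aromatic carbon and did not move this assay beyond the scatter.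

Compound 4 `CN(CCCN1CCCCC1)c1cccc(C(=O)N2CCc3ccc(OS(N)(=O)=O)cc3C2)c1` differs from compound 3 at that same place: methyl(3-(piperidin-1-yl)propyl)amino in place of ethyl(4-fluorobenzyl)amino on an aromatic carbon. Among the compounds with values here, no measured step covers this particular pair of groups, so the only guide is that the earlier amine swap, a number 9.4 percentage points lower from compound 2 to compound 3 (within the scatter), stayed within the scatter. On that basis the step of a number 3.5 percentage points higher from compound 3 to compound 4 (within the scatter) is expected to be small, with no clear direction beyond the scatter. Compound 4 is thus estimated at 70%, with a range from 50% to 88%.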

Compound 4, a percentage reported as inhibition, at one concentration (the size of the read-out at that concentration, not a potency): 30.6%
The estimate for compound 4 lay 39.4 percentage points above the measured number, and the stated range ends above it.
By their numbers in this assay, from the lowest: compound 4; then compounds 3 and 2 (each within the scatter of the next); then compound 1.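

In this assay, this place on the ring proves sensitive to what is attached: methyl(3-(piperidin-1-yl)propyl)amino gives a number 35.9 percentage points lower from compound 3 to compound 4 (beyond the scatter) and a number 45.3 percentage points lower from compound 2 to compound 4 (beyond the scatter), whereas the earlier amine swap did not leave the scatter. The change from ethyl(4-fluorobenzyl)amino keeps the same count of heavy atoms, so that count alone does not track the result; it replaces a six-membered aromatic ring of carbon only with a six-membered non-aromatic ring with one hetero atom and adds a second nitrogen. No measurement shown explains the fall. Still open, as far as these compounds go, is which part of the new group goes with the loss, since the methyl, propyl chain and piperidine ring all arrive together. A morpholine ring or a shorter ethyl chain in the same group would help separate these parts.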